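Trading a bromophenyl for a polar five-membered ring

The compounds below may be only part of what the source reports. "The series", "measured", "known", "first", "only" and "open" are said of these compounds alone.

This account follows a series of analogues built on the shared core of compound 1 `CN(CCNCc1cn(Cc2ccc(Br)cc2)nn1)CCNc1ccnc2cc(Cl)ccc12` and tested in a functional assay on HCC827 cells (Homo sapiens) for antiproliferative activity, read by sulforhodamine B assay, with a stated time of 72 h; a higher number here means a weaker inhibitor, a lower number a stronger inhibitor. Among the three measured members compound 1 gives 9300 nM, the lowest number of the set. Compound 2 `CN(CCNCc1cn(Cc2nc3cc(Cl)ccc3[nH]2)nn1)CCNc1ccnc2cc(Cl)ccc12` gives 65000 nM, and compound 3 `CN(CCNCc1cn(CC(=O)Nc2cccc3ccc(O)cc23)nn1)CCNc1ccnc2cc(Cl)ccc12` gives 86000 nM. Among the compounds with values here, the one step measured in one place, a 7.0-fold higher number from compound 1 to compound 2 (0.84 log units; beyond the scatter), replaced the 4-bromophenyl with a ring bearing hetero atoms and a hydrogen-bond donor, and the number rose beyond the scatter. Compound 4 `CN(CCNCc1cn(CCCn2nn[nH]c2=O)nn1)CCNc1ccnc2cc(Cl)ccc12` is the next analogue. Its change from compound 1 is a group of 8 heavy atoms (3 carbon, 4 nitrogen, 1 oxygen; one five-membered aromatic ring with 4 hetero atoms) in place of a group of 7 heavy atoms (6 carbon, 1 bromine; one six-membered aromatic ring of carbon only), on a saturated chain carbon bound to an aromatic nitrogen. Within the data shown here, the step from compound 1 to compound 2 is the only measured step that bears on this change, and there a hetero-rich aromatic ring in the same place weakened the inhibitor by a modest margin. Among the measured compounds shown here, the values of compound 3 point the same way, though no single-place step connects it to compound 1. The step of a 4.3-fold higher number from compound 1 to compound 4 (0.63 log units; beyond the scatter) is therefore expected to be a weakening of similar size. Compound 4 is estimated at 40000 nM, within a range from 15000 nM to 110000 nM.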

Compound 4, half-maximal inhibitory concentration: > 200000 nM
Compound 4: only a limit was reported; the forecaster's own chance of this, stated with the estimate: 10%; middle value at least 5.0-fold (0.69 log units) away from the limit.
By their numbers in this assay, from the lowest: compound 1; then compounds 2 and 3 (each within the scatter of the next). At a limit, above all of these: compound 4.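

Compound 4 reached only a limit of the assay: the limit of > 200000 nM in this assay, at which 1 of the 4 values shown sits. Its group, with a five-membered aromatic ring with 4 hetero atoms, gave an at least 21-fold higher number from compound 1 to compound 4 (1.33 log units; beyond the scatter), a large step, so this place can lose far more than the modest step to compound 2 had shown. The change also gave an at least 3.0-fold higher number from compound 2 to compound 4 (0.48 log units; beyond the scatter), which shows that hetero-rich aromatic groups at this place are not interchangeable, and that compound 2 does not mark the lower end of what the position tolerates.

As far as these compounds go, whether a plain phenyl without the bromine, or a 4-bromophenyl on a longer chain, would keep the number of compound 1 stays open. So does the question of whether an amine or a carboxylic acid at this place would fall with compound 2 or with compound 4.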